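Swapping an ethoxy for a carboxy on a tolerated scaffold

This account rests on a few compounds, and the source may have more. Where it says the series, first, only, none or still open, it means among the compounds named here.

Compound 1, `CCOc1ccc(C(=O)NNc2c(Br)cccc2Br)cc1`, is the starting point. Its read-out in a toxicity assay on MDCK cells (Canis lupus familiaris) for cytotoxicity, read by CCK-8 assay, with a stated time of 48 h (a higher number here means that more compound is tolerated, a lower number that less compound is tolerated), is not a number but a limit of the assay: compound 1 gives > 100000 nM. The same is true of compound 2, `O=C(NNc1c(Br)cccc1Br)c1ccc2ncccc2c1`, which in this assay also reaches only a limit, > 100000 nM. Compound 3, `CCOc1ccc(C(=O)NNc2ccccc2Br)cc1`, again stops at a limit in this assay, giving > 100000 nM. Only one pair among these differs in a single place, and that step is a step that the two limits leave unreadable from compound 1 to compound 3, so it carries no readable size. The whole picture is captured by the limit of > 100000 nM in this assay, at which 3 of the 3 values shown sit: none of the three compounds shows measurable toxicity within the tested range.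

Compound 4, `O=C(O)c1ccc(C(=O)NNc2c(Br)cccc2Br)cc1`, differs from compound 1 in one place: carboxy in place of ethoxy on an aromatic carbon. No measured step touches this kind of exchange, and the one step that is shown is unreadable, so there is nothing to point to a change in either direction. Given that compound 1 sits at a limit, compound 4 is expected to sit there as well, so the step that the limit leaves unreadable from compound 1 to compound 4 is an expectation of no change beyond the scatter. The estimate for compound 4 in this assay is therefore 200000 nM, with a range from 70000 nM to 600000 nM, and most likely the assay will again report only a limit.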

Compound 4, half-maximal cytotoxic concentration: > 100000 nM
Compound 4: a limit, no number; the forecaster's own chance of this, stated with the estimate: 85%; the middle value does not contradict the limit.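

In this assay compound 4 gives > 100000 nM as a limit of the assay and not a number. Compound 1 also stops at a limit, so the exchange between compound 1 and compound 4 has no readable size: the limit of > 100000 nM in this assay, at which 4 of the 4 values shown sit. Still open, as far as these compounds go, is the concentration at which any of these four compounds would harm the cells, and whether any single exchange would shift it.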